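The source may report more compounds than this note shows. Statements on the series, on what has been measured and on what is new or still open speak of the compounds shown alone.

In a functional assay on HT-1080 cells (Homo sapiens) for cytotoxicity, read by MTT assay, with a stated time of 72 h (a lower number here means a stronger inhibitor, a higher number a weaker inhibitor), three compounds built on a shared core have been measured. Compound 1 `COc1ccc(/C=C2\CCC/C(=C\c3ccc(Cl)cc3)C2=O)cc1OC` gives 4800 nM, compound 2 `COc1ccc(/C=C2\CCC/C(=C\c3cccc(Br)c3)C2=O)cc1OC` gives 5200 nM, and compound 3 `COc1ccc(/C=C2\CCC/C(=C\c3ccc(Br)cc3)C2=O)cc1OC` gives 4300 nM. Compound 3 thus stands level with the other two, and repeat measurements could not separate the three. Compound 4 `COc1cccc(/C=C2\CCC/C(=C\c3ccc(OC)c(OC)c3)C2=O)c1` has not yet been measured, and it departs from compound 3 in one place: 3-methoxyphenyl in place of 4-bromophenyl on a double-bonded chain carbon bound to a double-bonded ring carbon.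

Going by the values given here, three measured steps bear on this change. They are a 1.1-fold lower number from compound 1 to compound 3 (0.05 log units; within the scatter), a 1.1-fold higher number from compound 1 to compound 2 (0.03 log units; within the scatter) and a 1.2-fold lower number from compound 2 to compound 3 (0.08 log units; within the scatter), and all of them lie within the scatter. None of them brings in a methoxy group on this ring, however, so the evidence for the new group is only indirect. On these steps, no change beyond the scatter is expected in this assay, in either direction. The expected step is a 1.2-fold higher number from compound 3 to compound 4 (0.07 log units; within the scatter). For compound 4 the estimated value is 5000 nM, with an expected range of 2000 nM to 12000 nM.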

Compound 4, half-maximal inhibitory concentration: 4600 nM
Beside the measured number, compound 4's estimate is 1.1-fold (0.04 log units) above it; the measured number falls inside the stated range.
By their numbers in this assay, from the lowest: compounds 3, 4, 1 and 2 (each within the scatter of the next).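

The earlier compounds shown here varied only the halogen on this ring, and compound 4 shows that in this assay a ring carrying methoxy instead of a halogen also holds its place on a double-bonded chain carbon bound to a double-bonded ring carbon. The steps read a 1.1-fold higher number from compound 3 to compound 4 (0.03 log units; within the scatter) for 3-methoxyphenyl in place of 4-bromophenyl, a 1.1-fold lower number from compound 2 to compound 4 (0.05 log units; within the scatter) for methoxy in place of bromo, and a 1.0-fold lower number from compound 1 to compound 4 (0.02 log units; within the scatter) for 3-methoxyphenyl in place of 4-chlorophenyl, and all three lie within the scatter. Nothing available accounts for this flat result.

The compounds shown carry only halogen or methoxy on this ring, and none of them moves the number beyond the scatter. From the compounds shown here alone, whether an amine, a carboxylic acid or a longer chain at this place would do so remains open, as does whether the flat result holds in other cells.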